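The source may report more compounds than this note shows. Statements on the series, on what has been measured and on what is new or still open speak of the compounds shown alone.

Measured compounds in a functional assay on A549 cells (Homo sapiens) for inhibition, with a stated time of 72 h; on this read-out lower numbers stand for stronger inhibition and higher numbers for weaker inhibition:
compound 1 `COc1ccc(NC(=O)Nc2nc(Sc3c[nH]c4ccccc34)cc(N3CCN(c4ccccn4)CC3)n2)cc1`: > 50000 nM, a limit of the assay, not a number.
compound 2 `COc1ccc(NC(=O)Nc2nc(Nc3cc(OC)cc(OC)c3)cc(Sc3c[nH]c4ccccc34)n2)cc1`: > 50000 nM, a limit of the assay, not a number.
compound 3 `COc1ccc(NC(=O)Nc2nc(Sc3c[nH]c4ccccc34)cc(N3CCCC3)n2)cc1`: 11800 nM.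

Compound 2 stands at the limit of > 50000 nM in this assay, at which 2 of the 3 values shown sit; only a limit is known for it. Compound 4 `COc1cc(NC(=O)Nc2nc(Nc3cc(OC)cc(OC)c3)cc(Sc3c[nH]c4ccccc34)n2)cc(OC)c1` differs from compound 2 by 3,5-dimethoxyphenyl in place of 4-methoxyphenyl on an amide-type nitrogen. All three measured steps alter the substituent on the aromatic carbon of the shared core, not the aryl on the urea nitrogen: a step that the two limits leave unreadable from compound 1 to compound 2; an at least 4.2-fold lower number from compound 1 to compound 3 (0.62 log units; beyond the scatter); an at least 4.2-fold lower number from compound 2 to compound 3 (0.62 log units; beyond the scatter). None of these bears on the change from compound 2 to compound 4, and the (3,5-dimethoxyphenyl)amino group kept in compound 4 is the same one present in compound 2, which sits at the limit. For the measured compounds named here, with no measured step to read from, no step beyond the scatter is expected in this assay in either direction, so the estimated step is a number no higher from compound 2 to compound 4 (the limit leaves the size open), most likely ending again at a limit. Compound 4 is therefore expected at 50000 nM, between 20000 nM and 150000 nM.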

Compound 4, half-maximal inhibitory concentration: > 50000 nM
Compound 4 ended at the assay's limit; the forecaster's own chance of this, stated with the estimate: 75%; the middle value lies on the limit itself.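

In this assay compound 4 gives > 50000 nM, a limit of the assay. Compound 2 also sits at a limit, so no step can be read between compound 2 and compound 4. The compounds shown leave open whether 3,5-dimethoxyphenyl in place of 4-methoxyphenyl on the amide-type nitrogen shifts the read-out at all.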